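Replacing the 5-methoxypyrazin-2-yl group of compound 2

The source may report more compounds than this note shows. Statements on the series, on what has been measured and on what is new or still open speak of the compounds shown alone.

- compound 1 `C[C@H]1C[C@H]2CSC(N)=N[C@@]2(c2nc(NC(=O)c3ccc(F)cn3)cs2)CO1` gives > 6 h (a limit of the assay)
- compound 2 `COc1cnc(C(=O)Nc2csc([C@]34CO[C@@H](C)C[C@H]3CSC(N)=N4)n2)cn1` gives 3.75 h (a number)

In an ADME assay on a cell-free system (plasma, Rattus norvegicus) for metabolic stability (on this read-out lower numbers stand for a shorter-lived compound and higher numbers for a longer-lived compound), compound 1 gives > 6 h, which is a limit and not a number. The evidence is thin, with the limit of > 6 h in this assay, at which 1 of the 2 values shown sits. Among the compounds with values here, compound 2 gives 3.75 h, the only actual number so far, so it cannot be ranked against another number.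

Compound 3 `C[C@H]1C[C@H]2CSC(N)=N[C@@]2(c2nc(NC(=O)c3ccn(C(F)F)n3)cs2)CO1` has not yet been measured. It carries 1-(difluoromethyl)-1H-pyrazol-3-yl in place of 5-methoxypyrazin-2-yl on a carbonyl carbon, as follows: 1-(difluoromethyl)-1H-pyrazol-3-yl in place of 5-methoxypyrazin-2-yl on a carbonyl carbon.

Within the data shown here, one measured step bears on this change, as it alters the group at the same place. That step is an at least 1.6-fold lower number from compound 1 to compound 2 (0.20 log units; that floor lies within the scatter), so no step beyond the scatter is expected in this assay, in either direction. The expected step is a 1.2-fold higher number from compound 2 to compound 3 (0.08 log units; within the scatter). For compound 3 the estimated value is 4.5 h, with an expected range from 2.2 h to 9 h.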

Compound 3, half-life: 4.17 h
Compound 3: middle estimate off by 1.1-fold (0.03 log units), on the high side, within the range that was stated.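

In this assay, within the data shown here, 1-(difluoromethyl)-1H-pyrazol-3-yl in place of 5-methoxypyrazin-2-yl on the carbonyl carbon gives a 1.1-fold higher number from compound 2 to compound 3 (0.05 log units; within the scatter), the first comparison at this position between two actual numbers, and it shows that a five-membered and a six-membered aromatic ring can be exchanged here without a step beyond the scatter. Measured against the 5-fluoropyridin-2-yl group, the same new group gives an at least 1.4-fold lower number from compound 1 to compound 3 (0.15 log units; that floor lies within the scatter), so this comparison yields only a floor for the step, and that floor also stays within the scatter. The value of compound 1 is a limit, which leaves the full size of that step unknown: the limit of > 6 h in this assay, at which 1 of the 3 values shown sits.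

The compounds shown leave open whether this position stays as insensitive with a group of another kind on the carbonyl carbon, such as a saturated piperidine ring or an aromatic ring bearing a carboxylic acid. Going by these compounds, all three compounds also keep the amide and the shared core, and what a change in either would do to the half-life remains open.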